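Nitro in place of fluoro on the pendant aryl of compound 3

The source may hold more compounds than are shown below. What is called first, only, known or untested is meant among the compounds shown, and "the series" means these compounds.

Measured so far in a functional assay on FOCUS cells (Homo sapiens) for inhibition, read by sulforhodamine B assay, with a stated time of 72 h; on this read-out lower numbers stand for stronger inhibition and higher numbers for weaker inhibition:
compound 1 `CC(c1ccc(-c2ccccc2)c(F)c1)c1nnc2n1N=C(c1ccc(Cl)cc1Cl)CS2`: 5400 nM
compound 2 `CC(c1ccc(-c2ccccc2)c(F)c1)c1nnc2n1N=C(c1ccc(Cl)cc1)CS2`: 5000 nM
compound 3 `CC(c1ccc(-c2ccccc2)c(F)c1)c1nnc2n1N=C(c1ccc(F)cc1)CS2`: 3500 nM

All three compounds share the same core and differ only in the aryl group on the carbon with a double bond to nitrogen. Compound 3 carries the 4-fluorophenyl there. The steps of a 1.5-fold lower number from compound 1 to compound 3 (0.19 log units; within the scatter) and a 1.4-fold lower number from compound 2 to compound 3 (0.15 log units; within the scatter), as well as a 1.1-fold lower number from compound 1 to compound 2 (0.03 log units; within the scatter), are all within the scatter, so on these numbers the three compounds stand together and no ordering among them can be read.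

Compound 4 `CC(c1ccc(-c2ccccc2)c(F)c1)c1nnc2n1N=C(c1ccc([N+](=O)[O-])cc1)CS2` is the next member. It differs from compound 3 by nitro in place of fluoro on an aromatic carbon. Going by the values given here, no measured step exchanges fluoro for nitro; the nearest comparisons are the halogen changes at the same aromatic carbon, and those moved nothing beyond the scatter. Since every change on this aryl so far has left this assay unmoved, the expectation for compound 4 is a step of no change at the digits printed from compound 3 to compound 4 (within the scatter), that is, none beyond the scatter, in either direction. The estimate for compound 4 in this assay is therefore 3500 nM, with a range from 1400 nM to 9000 nM, the width reflecting that a nitro group has not yet been tried on this position.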

Compound 4, half-maximal inhibitory concentration: 3500 nM
The estimate for compound 4 equals the measured number at the digits printed; low and high end bracket the measured number.
By their numbers in this assay, from the lowest: compounds 3, 4, 2 and 1 (each within the scatter of the next).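

In this assay the pendant aryl now tolerates a nitro group as well as halogens, with no change at the digits printed from compound 3 to compound 4 (within the scatter), a 1.4-fold lower number from compound 2 to compound 4 (0.15 log units; within the scatter) and a 1.5-fold lower number from compound 1 to compound 4 (0.19 log units; within the scatter). Exchanging fluoro for nitro brings three heavy atoms in place of one and adds two hydrogen-bond acceptors, yet compound 1, compound 2, compound 3 and compound 4 still stand together, so this position has so far shown no response to a change that goes beyond the halogens. No supporting data bear on why this position gives no separation.

Open, on these data alone, is whether an amine or a carboxylic acid on the same aromatic carbon would move the number beyond the scatter. Also open, as far as these compounds go, is whether changes elsewhere on the shared core would do so.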